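Dropping One Chloro From a Cytotoxic Core

The source may hold more compounds than are shown below. What is called first, only, known or untested is meant among the compounds shown, and "the series" means these compounds.

Measured compounds:
- compound 1, `ClCc1ccccc1Cn1cnc2c(Cl)nc(Cl)nc21`: 7070 nM
- compound 2, `Nc1nc(Cl)c2ncn(Cc3ccc(CCl)cc3)c2n1`: 53700 nM

In a functional assay on IGROV-1 cells (Homo sapiens) for cytotoxicity, read by sulforhodamine B assay, with a stated time of 48 h (on this read-out higher numbers stand for lower toxicity in this test and lower numbers for higher toxicity in this test), compound 1 gives 7070 nM, the lower of the two numbers shown. Compound 2 gives 53700 nM in this assay, and the gap between the two lies beyond the usual scatter, so compound 1 is clearly the more toxic of the pair in this test. Within the data shown here, the two structures differ in more than one place, so no single step between them can be traced.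

Compound 3, `ClCc1ccccc1Cn1cnc2c(Cl)ncnc21`, has not yet been measured. It differs from compound 1 in one place: hydrogen in place of chloro on an aromatic carbon, in words, hydrogen in place of chloro on an aromatic carbon. Among the measured compounds shown here, no measured pair shows what such a change does, so the expectation rests on compound 1 alone and is uncertain. A modest loss of toxicity is expected, though a step within the scatter would not surprise; the expected step is a 2.1-fold higher number from compound 1 to compound 3 (0.33 log units; beyond the scatter). Compound 3 is therefore expected to give 15000 nM in this assay, with a range from 5000 nM to 50000 nM.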

Compound 3, concentration lethal to 50% of the cells: 55000 nM
Compound 3: the middle estimate sits 3.7-fold (0.56 log units) below what was measured; measured number outside the range, above it.
By their numbers in this assay, from the lowest: compound 1; then compounds 2 and 3 (each within the scatter of the next).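

In this assay, replacing chloro with hydrogen on an aromatic carbon between two ring nitrogen atoms gives a 7.8-fold higher number from compound 1 to compound 3 (0.89 log units; beyond the scatter). Among these compounds, compounds 1 and 3 differ only at this place, so this is the first direct reading of a single change: here, the loss of this chloro goes with lower toxicity in this test, by a step beyond the usual scatter. Nothing available explains why removing this one atom shifts the number by this much.

On these data alone, this single pair shows only the two ends of one swap, chloro and hydrogen, so it remains open whether a fluorine atom, a methoxy group or a nitrile at the same place would keep the toxicity of compound 1 or lose it as compound 3 does. Also open, as far as these compounds go, is whether replacing the chloro group that stays in compound 3, meta to the changed place, with hydrogen would produce a step of similar size.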